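The compounds below may be only part of what the source reports. "The series", "measured", "known", "first", "only" and "open" are said of these compounds alone.

Measured so far in a functional assay on Venous blood for antagonist activity at C-X-C chemokine receptor type 3 (Homo sapiens), read by flow cytometry, with a stated time of 30 min, in the presence of a further agent that is not named here; on this read-out lower numbers stand for stronger inhibition and higher numbers for weaker inhibition:
- compound 1, `C[C@@H]1CN(c2sc(C(F)(F)F)nc2-c2nc3ccccc3[nH]2)CCN1C(=O)Cn1cccn1`: 191 nM
- compound 2, `C[C@@H]1CN(c2sc(C(F)(F)F)nc2-c2nc3ccccc3n2C)CCN1C(=O)Cn1cccn1`: 3560 nM

Compound 1 holds the lower of the two numbers. Among the measured compounds shown here, the one measured step, a 19-fold higher number from compound 1 to compound 2 (1.27 log units; beyond the scatter), concerns methyl in place of hydrogen on an aromatic nitrogen and leaves the chain bearing the pyrazolyl untouched; it therefore does not bear on the change now in question.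

Compound 3, `C[C@@H]1CN(c2sc(C(F)(F)F)nc2-c2nc3ccccc3[nH]2)CCN1C(=O)CN1C(=O)OC[C@@H]1c1ccccc1`, differs from compound 1 as follows: 2-oxo-4-phenyl-1,3-oxazolidin-3-yl in place of 1H-pyrazol-1-yl on a saturated chain carbon bound to a carbonyl carbon. For the measured compounds named here, no measured step covers this position, so no direction can be argued from the data. Compound 3 is expected to lie near compound 1, with a wide range: an estimated 300 nM (range 60 nM to 1500 nM), i.e. an expected 1.6-fold higher number from compound 1 to compound 3 (0.20 log units; within the scatter).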

Compound 3, half-maximal inhibitory concentration: 1380 nM
Compound 3: middle estimate off by 4.6-fold (0.66 log units), on the low side; the range from low to high includes it.
By their numbers in this assay, from the lowest: compound 1; then compound 3; then compound 2.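

Among the compounds shown here, the first measured change at this position, on a saturated chain carbon bound to a carbonyl carbon, shows that inhibition depends on the group placed there: 2-oxo-4-phenyl-1,3-oxazolidin-3-yl in place of 1H-pyrazol-1-yl gives a 7.2-fold higher number from compound 1 to compound 3 (0.86 log units; beyond the scatter). The entering group differs from 1H-pyrazol-1-yl in several ways at once, including its non-aromatic ring, its phenyl ring and its defined stereocentre, so this single step cannot assign the change to any one of them. No measurement bears on the origin of this step.

The compounds shown leave open whether other aromatic rings at this position match 1H-pyrazol-1-yl. From the compounds shown here alone, the effect of an amine or a carboxylic acid on this chain carbon also remains open.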